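Trifluoromethoxy in Place of Trifluoromethyl on Compound 1

The source may report more compounds than this note shows. Statements on the series, on what has been measured and on what is new or still open speak of the compounds shown alone.

After a dose enters the bloodstream, a compound may stay largely in the blood or spread into the tissues. Of the compounds shown here, three have been measured for this in an ADME assay on the whole organism (strain Balb/c) for pharmacokinetics, with Mus musculus as the target, read by LC-MS, at a dose of 3 mg/kg by the intravenous route (on this read-out higher numbers stand for wider distribution into tissues and lower numbers for narrower distribution), so far. Compound 1 `CC(Oc1ccc(F)c(C(N)=O)c1F)c1nc(-c2ccc(C(F)(F)F)cc2)c(Br)o1` gives 2 L/kg and is the lowest of the three. Compound 2 `CCc1oc(COc2ccc(F)c(C(N)=O)c2F)nc1-c1ccc(OC)cc1` gives 4.3 L/kg and compound 3 `CCCc1oc(COc2ccc(F)c(C(N)=O)c2F)nc1-c1ccc(Cl)cc1` gives 5 L/kg on the same measure. Both lie beyond the usual scatter from compound 1, but each differs from it in several places, so neither isolates a single change.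

Compound 4 `CC(Oc1ccc(F)c(C(N)=O)c1F)c1nc(-c2ccc(OC(F)(F)F)cc2)c(Br)o1` differs from compound 1 in one place only, with trifluoromethoxy in place of trifluoromethyl on an aromatic carbon, para to a large group (trifluoromethoxy in place of trifluoromethyl on an aromatic carbon). Within the data shown here, no measured pair shows what this exchange does, so any forecast has to start from compound 1 at (2 L/kg) and stay close to it. A small upward drift in this assay seems the likeliest outcome, leaning slightly toward the higher numbers of the other two compounds. The expected change is an estimated 1.3-fold higher number from compound 1 to compound 4 (0.10 log units; within the scatter) and would stay within the usual scatter. Compound 4 is expected to read 2.5 L/kg (range 1.3 L/kg to 4.6 L/kg) when measured.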

Compound 4, volume of distribution: 2.7 L/kg
Compound 4: middle estimate off by 1.1-fold (0.03 log units), on the low side, within the range that was stated.
By their numbers in this assay, from the lowest: compounds 1, 4, 2 and 3 (each within the scatter of the next, the first and the last beyond it).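

Among these compounds, compound 4 gives the first comparison in this assay in which only one place differs, and the exchange of trifluoromethyl for trifluoromethoxy on this aromatic carbon, para to a large group, amounts to a 1.4-fold higher number from compound 1 to compound 4 (0.13 log units; within the scatter). That step lies within the usual scatter of repeated measurements, so on this read-out the two compounds cannot be told apart, and adding the oxygen atom that links the fluorinated carbon to the ring leaves no change that can be distinguished here. This is a single pair on one core, so it describes this exchange on compound 1 and sets no general rule, and nothing available explains the result.

The compounds shown leave open whether a group of a different kind at this position, such as an amine, a carboxylic acid or a longer chain, would move the reading beyond the scatter. They also leave open whether trifluoromethoxy in place of trifluoromethyl would give a similarly small step on a compound other than compound 1.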